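A Ring Amine Replaces Propargylamino on the Carbonyl

A few compounds are considered here, and "the series" means these few. Any claim that something is new, unique, unknown or untested is made for them only; others in the source may bear on it.

Measured compounds and their values:
compound 1, `COc1ccc(/C=C/c2cc(OC)cc(OC)c2/C=C/C(=O)N2CCN(C)CC2)cc1`, gives 5670 nM
compound 2, `C#CCNC(=O)/C=C/c1c(/C=C/c2ccc(OC)cc2)cc(OC)cc1OC`, gives 8280 nM
compound 3, `CCCCCN(CCCCC)C(=O)/C=C/c1c(/C=C/c2ccc(OC)cc2)cc(OC)cc1OC`, gives 9270 nM

The three measured compounds share one core and differ only in the amine attached to the carbonyl carbon. In a functional assay on B16-F10 cells (Mus musculus) for inhibition, read by MTT assay, with a stated time of 48 h (a higher number here means a weaker inhibitor, a lower number a stronger inhibitor), compound 2 gives 8280 nM; this stands second highest of the three numbers, closest to compound 3 and furthest from compound 1, yet all three values lie within the usual scatter of one another, so none can be called stronger or weaker than the others.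

Compound 4, `COc1ccc(/C=C/c2cc(OC)cc(OC)c2/C=C/C(=O)N2CCCC(C)C2)cc1`, is not yet measured. It differs from compound 2 in one place: 3-methylpiperidin-1-yl in place of propargylamino on a carbonyl carbon.

For the measured compounds named here, two measured steps touch the same carbonyl carbon: a 1.5-fold higher number from compound 1 to compound 2 (0.16 log units; within the scatter) and a 1.1-fold higher number from compound 2 to compound 3 (0.05 log units; within the scatter). In both, exchanging one amine for another, whether a ring amine for a chain amine or a small chain for two long chains, left the result within the scatter. The change to compound 4 brings back a ring amine, much as compound 1 carries one, and compound 1 gives 5670 nM.

Compound 4 is therefore expected to show a 1.3-fold lower number from compound 2 to compound 4 (0.11 log units; within the scatter), a step that stays within the scatter. The estimate for compound 4 is 6500 nM, with a range from 3000 nM to 14000 nM.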

Compound 4, half-maximal inhibitory concentration: 8250 nM
The estimate for compound 4 lay 1.3-fold (0.10 log units) below the measured number; the range from low to high includes it.
By their numbers in this assay, from the lowest: compounds 1, 4, 2 and 3 (each within the scatter of the next).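

Placing 3-methylpiperidin-1-yl on the carbonyl carbon in place of propargylamino removes the triple bond and the hydrogen-bond donor and adds a six-membered non-aromatic ring, yet in this assay the result is (a 1.0-fold lower number from compound 2 to compound 4 (0.00 log units; within the scatter)). The same ring amine also stays within the scatter when it replaces dipentylamino (a 1.1-fold lower number from compound 3 to compound 4 (0.05 log units; within the scatter)) or 4-methylpiperazin-1-yl (a 1.5-fold higher number from compound 1 to compound 4 (0.16 log units; within the scatter)), so all four amines now give numbers that cannot be told apart in this assay, and the earlier hint that a ring amine might set compound 1 apart finds no support in compound 4. No independent measurement is available to explain this flat result.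

The compounds shown leave open whether any group on this carbonyl carbon can move the number beyond the scatter, for example a carboxylic acid in place of the amide or an aromatic amine such as aniline. They also leave open whether a change elsewhere on the shared core, such as replacing a methoxy group with a hydroxyl group, would matter more than the choice of amine.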